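The source may report more compounds than this note shows. Statements on the series, on what has been measured and on what is new or still open speak of the compounds shown alone.

Measured so far in a functional assay on PC-3 cells (Homo sapiens) for inhibition; a lower number here means that less compound is needed, a higher number that more compound is needed for the effect:
- compound 1 `CC(C(=O)SCCCCCCC(=O)Nc1nc(-c2ccccc2)cs1)c1ccccc1`: 37000 nM
- compound 2 `C[C@H](Cc1ccccc1)C(=O)SCCCCCCC(=O)Nc1nc(-c2ccccc2)cs1`: 9900 nM

Compound 2 holds the lower of the two numbers in this assay, so less of it is needed for the effect. For the measured compounds named here, the one measured step, a 3.7-fold lower number from compound 1 to compound 2 (0.57 log units; beyond the scatter), comes with 1-benzylethyl in place of 1-phenylethyl on a carbonyl carbon, and it lies beyond the scatter.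

The next compound is compound 3 `C[C@@H](Cc1ccccc1)C(=O)SCCCCCCC(=O)Nc1nc(-c2ccccc2)cs1`: the two compounds have the same atoms and bonds and differ only in configuration as drawn: 1 of 1 stereo elements differ; a stereocentre at a saturated chain carbon is drawn R in compound 2 and S in compound 3. The measured step swaps one group for another, so it bears only indirectly on this change. Going by the values given here, no measured pair here differs in configuration alone. It does show that a change at this group can move the number modestly, so a shift of similar or smaller size is expected. Among the compounds with values here, the direction is open, and a lean toward a higher number is only a guess, resting on compound 2 at 9900 nM being the lowest number so far.

The expected step is a 1.3-fold higher number from compound 2 to compound 3 (0.12 log units; within the scatter). For compound 3 the estimated value is 13000 nM, with an expected range from 4500 nM to 38000 nM.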

Compound 3, half-maximal effective concentration: 4400 nM
Beside the measured number, compound 3's estimate is 3.0-fold (0.47 log units) above it; measured number below the stated range.
By their numbers in this assay, from the lowest: compound 3; then compound 2; then compound 1.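

The earlier compounds shown here could not show whether the drawn configuration at this saturated chain carbon matters on its own, and in this assay it does, with a 2.3-fold lower number from compound 2 to compound 3 (0.35 log units; beyond the scatter). That shift can be assigned to this single stereocentre, with the S form giving the lower number, because nothing else separates the pair: the fact that compounds 2 and 3 differ only in the configuration as drawn. The swap of 1-phenylethyl for 1-benzylethyl on the carbonyl carbon also looks different now, since its size depends on the configuration drawn, and the S form gives an 8.4-fold lower number from compound 1 to compound 3 (0.92 log units; beyond the scatter).

As far as these compounds go, compound 1 is drawn with no configuration at its own stereocentre, so how each single form of the 1-phenylethyl group would compare with compound 2 and compound 3 stays open. It is also open whether the preference for the S form would hold if 1-benzylethyl gave way to a longer chain or carried an amine, and the shown compounds say nothing about why this configuration gives the lower number.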